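A few compounds are considered here, and "the series" means these few. Any claim that something is new, unique, unknown or untested is made for them only; others in the source may bear on it.

In an ADME assay on S9 fraction from liver (Homo sapiens) for metabolic stability, read by LC-MS, using NADPH, with stated times of 5 min and 60 min, tested at 5 uM (a lower number here means that less of the compound is left, a higher number that more of the compound is left), compound 1 `COc1cc(C2CN(C(=O)c3cc(OCCO)ccn3)C2)ccc1OCc1ccc(C2CC2)cc1` gives 47% and compound 2 `COc1cc(C2CN(C(=O)c3cc(OC[C@H](O)CO)ccn3)C2)ccc1OCc1ccc(C2CC2)cc1` gives 64%. Compound 3 `CCc1ccc(COc2ccc(C3CN(C(=O)c4cc(COC[C@@H](O)CO)ccn4)C3)cc2OC)cc1` gives 54%, which lies within the usual scatter of both of the others, so no order can be read between compound 3 and either of them. Compound 4 `CCc1ccc(COc2ccc(C3CN(C(=O)c4cc(COCC(CO)(CO)CO)ccn4)C3)cc2OC)cc1` differs from compound 3 on a saturated chain carbon bound to an oxygen on a saturated carbon: 2-hydroxy-1,1-bis(hydroxymethyl)ethyl in place of 1,2-dihydroxyethyl on a saturated chain carbon bound to an oxygen on a saturated carbon. The chain end thus gains hydroxymethyl groups, and the defined stereocentre is gone. Going by the values given here, only one measured step resembles this change. Hydroxymethyl in place of hydrogen on a similar chain gave a number 17 percentage points higher from compound 1 to compound 2 (beyond the scatter), a modest step beyond the scatter. That is a single case, and compound 1 and compound 2 also differ from compound 3 elsewhere in their structures, so it is weak support. A smaller move in the same direction is therefore expected, namely a number 8 percentage points higher from compound 3 to compound 4 (within the scatter). For compound 4 the estimated value is 62%, with an expected range from 45% to 79%.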

Compound 4, percent of the compound remaining in the Homo sapiens assay: 61%
Estimate against measurement, compound 4: 1 percentage points above, within the range that was stated.
By their numbers in the Homo sapiens assay, from the lowest: compounds 1, 3, 4 and 2 (each within the scatter of the next, the first and the last beyond it).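

In the Homo sapiens assay, a number 7 percentage points higher from compound 3 to compound 4 (within the scatter), so on a saturated chain carbon bound to an oxygen on a saturated carbon, 2-hydroxy-1,1-bis(hydroxymethyl)ethyl can replace 1,2-dihydroxyethyl, and the defined stereocentre can go, without a change that can be read. Going by these compounds alone, the earlier compounds offered only one step of this kind, and it lay beyond the scatter, whereas this one does not. The same swap does give a readable difference in a physicochemical assay for solubility, in phosphate buffer, at pH 7.2 (a lower number here means a less soluble compound, a higher number a more soluble compound), where compound 3 gives 7100 nM and compound 4 gives 2800 nM: the measured solubility of compound 3, 7100 nM, and of compound 4, 2800 nM, a 2.5-fold lower number (0.40 log units; beyond the scatter)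

This rests on a single pair of compounds, so it cannot be said to hold for other chains or cores. The compounds shown leave open how a chain end carrying an amine or a carboxylic acid would read in the Homo sapiens assay and in the physicochemical assay.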